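The source may report more compounds than this note shows. Statements on the series, on what has been measured and on what is new or still open speak of the compounds shown alone.

Measured compounds:
compound 1 `O=C(/C=C/c1ccc2c(c1)B(O)OC2)c1ccc(Cl)cc1`: 9300 nM
compound 2 `O=C(/C=C/c1ccc2c(c1)B(O)OC2)c1ccc(OCc2ccccc2)cc1`: 12100 nM
compound 3 `O=C(/C=C/c1ccc2c(c1)B(O)OC2)c1ccc(C(F)(F)F)cc1`: 6300 nM

In a functional assay on HCT-116 cells (Homo sapiens) for cytotoxicity, read by MTT assay, with a stated time of 48 h (a higher number here means a weaker inhibitor, a lower number a stronger inhibitor), compound 1 gives 9300 nM, the second highest of the three numbers. Its nearest neighbour is compound 2, with a 1.3-fold higher number from compound 1 to compound 2 (0.11 log units; within the scatter); its furthest is compound 3, with a 1.5-fold lower number from compound 1 to compound 3 (0.17 log units; within the scatter). The remaining pair shows a 1.9-fold lower number from compound 2 to compound 3 (0.28 log units; within the scatter). All three steps stay within the scatter, so the three measured compounds cannot be ordered.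

Compound 4 `O=C(/C=C/c1ccc2c(c1)B(O)OC2)c1cccc(F)c1` differs from compound 1 in one place: 3-fluorophenyl in place of 4-chlorophenyl on a carbonyl carbon. Every measured step swaps one group for another on an aromatic carbon, while the change here replaces the whole 4-chlorophenyl by 3-fluorophenyl. For the measured compounds named here, no measured step covers such a change, so the three steps bear on it only indirectly; their message is that variation of this ring, so far, moved this assay by nothing beyond the scatter. Compound 4 is therefore expected to give 9000 nM, within 4000 nM to 20000 nM. This estimate means an expected step of a 1.0-fold lower number from compound 1 to compound 4 (0.01 log units; within the scatter), not beyond the scatter.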

Compound 4, half-maximal inhibitory concentration: 6700 nM
The estimate for compound 4 lay 1.3-fold (0.13 log units) above the measured number, and the stated range covers the measured number.
By their numbers in this assay, from the lowest: compounds 3, 4, 1 and 2 (each within the scatter of the next).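

In this assay, the exchange of 4-chlorophenyl for 3-fluorophenyl on the carbonyl carbon gives a 1.4-fold lower number from compound 1 to compound 4 (0.14 log units; within the scatter). For the compounds shown here, the earlier steps swapped only one group on an aromatic carbon, whereas this one alters both the halogen and its place on the ring, and the number still stays within the scatter. The two alterations cannot be separated from this single step, and nothing shown explains the result.

The compounds shown leave open whether any group on this ring can move the number beyond the scatter, for instance an amine or a carboxylic acid. They also leave open what happens when the ring on the carbonyl carbon is replaced by something other than a substituted phenyl, such as a cyclohexyl ring or a longer chain.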